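Series notes: ester to tertiary amide on the dienoate chain

This account rests on a few compounds, and the source may have more. Where it says the series, first, only, none or still open, it means among the compounds named here.

Three compounds of the series have numbers in a physicochemical assay for lipophilicity; on this read-out lower numbers stand for lower lipophilicity and higher numbers for higher lipophilicity. Compound 1 `COC(C)(C)CCCC(C)C/C=C/C(C)=C/C(=O)OC1CC1` gives 5.71 in this assay, the second highest of the three. Compound 2 `CCOC(=O)/C=C(C)/C=C/CC(C)CCC(O)C(C)C` gives 4.65, a number beyond the scatter below compound 1. Compound 3 `CC(/C=C/CC(C)CCCC(C)C)=C\C(=O)SC(C)C` gives 8.39, further away and beyond the scatter above compound 1. Going by the values given here, no pair among the measured compounds differs in a single place, so no measured step is available to set the size of a change.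

Compound 4 `CCN(CC)C(=O)/C=C(C)/C=C/CC(C)CCCC(C)(C)OC` is not yet measured. It differs from compound 1 in one place: diethylamino in place of cyclopropyloxy on a carbonyl carbon. The step from a cyclopropyloxycarbonyl to a diethylcarbamoyl group is expected to move this assay downward, and the expected size is a number 0.71 log units lower from compound 1 to compound 4 (beyond the scatter), somewhat beyond the scatter rather than within it. On that basis compound 4 is expected to give about 5 in this assay, with a range from 4.3 to 5.7; the number of compound 1 at 5.71 is the anchor for this estimate, and nothing in the measured set checks it directly.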

Compound 4, partition coefficient: 4.82
Beside the measured number, compound 4's estimate is 0.18 log units above it, and the stated range covers the measured number.
By their numbers in this assay, from the lowest: compounds 2 and 4 (each within the scatter of the next); then compound 1; then compound 3.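

The series now holds its first measured step in one place: in this assay the exchange of cyclopropyloxy for diethylamino on a carbonyl carbon gives a number 0.89 log units lower from compound 1 to compound 4 (beyond the scatter) and so sets a size for this change at this position. The entering group has more heavy atoms than the leaving one and no ring, yet the number falls, so in this pair a higher heavy-atom count at this place does not go with a higher number. Nothing in hand explains the size of this step.

One pair cannot separate the carbonyl-bound nitrogen from its two ethyl groups; dimethylamino, pyrrolidin-1-yl or a carboxylic acid at the same carbonyl carbon would bear on that. On these data alone, whether the step carries over to the other chain ends of the series also remains open.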